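The source may hold more compounds than are shown below. What is called first, only, known or untested is meant among the compounds shown, and "the series" means these compounds.

Measured compounds in the series so far:

- compound 1, `C[C@H]1CC[C@@H]2[C@@H](OC(=O)[C@]23CC(c2c(Cl)cccc2Cl)=NO3)[C@]2(C)C(=O)C=C[C@@]12O`: 2.67
- compound 2, `C[C@H]1CC[C@@H]2[C@@H](OC(=O)[C@]23CC(c2ccccc2)=NO3)[C@]2(C)C(=O)C=C[C@@]12O`: 1.41

In a physicochemical assay for lipophilicity (on this read-out higher numbers stand for higher lipophilicity and lower numbers for lower lipophilicity), compound 1 stands highest of the two numbers measured; its nearest neighbour is compound 2, and the step of a number 1.26 log units lower from compound 1 to compound 2 (beyond the scatter) is large and beyond the scatter. That step is the only one measured at this position, the carbon with a double bond to nitrogen of the five-membered ring.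

The next compound is compound 3, `C[C@H]1CC[C@@H]2[C@@H](OC(=O)[C@]23CC(c2ccccc2F)=NO3)[C@]2(C)C(=O)C=C[C@@]12O`. Its change from compound 1 is 2-fluorophenyl in place of 2,6-dichlorophenyl on a carbon with a double bond to nitrogen. This step bears directly on the measured one: both remove the 2,6-dichlorophenyl from the same carbon, and the 2-fluorophenyl that enters is closer in its count of heavy atoms to the phenyl of compound 2 than to the group that leaves. A drop in this assay is therefore expected, somewhat smaller than the step to compound 2 because a number 1.26 log units lower from compound 1 to compound 2 (beyond the scatter) removed two chlorines and here one fluorine remains in their place; the expected step is a number 1.07 log units lower from compound 1 to compound 3 (beyond the scatter).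

For compound 3 in this assay the estimate is 1.6, with a range of 1.2 to 2.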

Compound 3, partition coefficient: 1.58
Beside the measured number, compound 3's estimate is 0.02 log units above it; low and high end bracket the measured number.
By their numbers in this assay, from the lowest: compounds 2 and 3 (each within the scatter of the next); then compound 1.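

In this assay, a second replacement of 2,6-dichlorophenyl on the carbon with a double bond to nitrogen gives a number 1.09 log units lower from compound 1 to compound 3 (beyond the scatter), so the large fall seen with compound 2 no longer rests on one compound. Fluoro in place of hydrogen on an aromatic carbon gives a number 0.17 log units higher from compound 2 to compound 3 (within the scatter), so at this position 2-fluorophenyl and phenyl cannot be told apart on this read-out, while 2,6-dichlorophenyl stands apart from both by a step beyond the scatter. Nothing in hand accounts for either step.

Compounds 1, 2 and 3 do not settle whether one chlorine, as in 2-chlorophenyl, would give a number close to that of compound 1, close to those of compounds 2 and 3, or somewhere in between. Also open, going by these compounds, is how far the number would move with a different kind of group on the same aromatic ring, such as an amine or a carboxylic acid, or with a saturated ring or a longer chain in place of the aromatic ring on this carbon.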